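A Chloro Removed From the Amide-Bearing Ring

The source may report more compounds than this note shows. Statements on the series, on what has been measured and on what is new or still open speak of the compounds shown alone.

Measured so far in a functional assay on KG-1 cells (Homo sapiens) for cytotoxicity, read by luminescence and CellTiter-Glo, with a stated time of 3 days; on this read-out higher numbers stand for weaker inhibition and lower numbers for stronger inhibition:
- compound 1, `O=C(Nc1cc(C(F)(F)F)cc(C(F)(F)F)c1)c1ccc(-c2ccccc2)cc1O`: 860 nM
- compound 2, `O=C(Nc1ccc(Cl)cc1Cl)c1ccc2cccnc2c1O`: 3560 nM

Of these two, compound 2 gives the higher number, so it is the weaker inhibitor; compound 1 gives the lower number, and that gap lies beyond the usual scatter. Compound 3, `O=C(Nc1ccc(Cl)cc1)c1ccc2cccnc2c1O`, has not been measured yet. It differs from compound 2 in one place: hydrogen in place of chloro on an aromatic carbon. Among the compounds with values here, no pair of measured compounds shows the effect of taking away a chloro on this ring, so the size of this step is unknown. A modest rise in the number is expected, not much beyond the scatter, since compound 2 already stands at 3560 nM. The step from compound 2 to compound 3 is estimated at a 1.7-fold higher number from compound 2 to compound 3 (0.23 log units; within the scatter). In this assay compound 3 is expected to give about 6000 nM, somewhere between 2000 nM and 18000 nM.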

Compound 3, half-maximal inhibitory concentration: 3300 nM
Compound 3: the middle estimate sits 1.8-fold (0.26 log units) above what was measured; the measured number falls inside the stated range.
By their numbers in this assay, from the lowest: compound 1; then compounds 3 and 2 (each within the scatter of the next).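

In this assay, replacing this chloro, ortho to a large group and meta to a chloro group, with hydrogen gives a 1.1-fold lower number from compound 2 to compound 3 (0.03 log units; within the scatter). Within the data shown here, for this pair, then, the chloro at this place is not needed to keep the number where it stands, and the single remaining chloro in compound 3 is enough to give a value matching that of compound 2. No measurement shown here offers an explanation for this result.

Going by these compounds, the effect of other groups at this same place, such as a methoxy group or an amine, remains open. So does the contribution of the chloro that compound 2 and compound 3 share, since no compound shown here has lost or replaced it on this core.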